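From an Imidazole Sulfonamide to a Chloropyridine

The compounds below may be only part of what the source reports. "The series", "measured", "known", "first", "only" and "open" are said of these compounds alone.

Of the compounds shown here, three built on a shared core have been tested in a functional assay on DLD-1 cells (Homo sapiens) for antiproliferative activity, read by CellTiter-Glo, with a stated time of 72 h; a lower number here means a stronger inhibitor, a higher number a weaker inhibitor. Compound 1 `CC1CCN(C2CCN(S(=O)(=O)c3cn(C)cn3)CC2)CC1` reaches only the assay limit of > 5000 nM, so its true value is not known. Where compound 1 stands is thus set by the limit of > 5000 nM in this assay, at which 2 of the 3 values shown sit. Compound 2 `CC1CCN(C2CCN(S(=O)(=O)c3cn(C)c(=O)n(C)c3=O)CC2)CC1` likewise gives only the limit > 5000 nM. Compound 3 `Cc1cc(C)c(S(=O)(=O)N2CCC(N3CC(C)CC(C)C3)CC2)c(C)c1`, which carries a six-membered aromatic ring on the sulfonyl sulfur, gives 17 nM in this assay.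

Compound 4 `CC1CCN(C2CCN(S(=O)(=O)c3ccc(Cl)nc3)CC2)CC1` has not yet been measured. It differs from compound 1 in one place: 6-chloropyridin-3-yl in place of 1-methyl-1H-imidazol-4-yl on a sulfonyl sulfur. Among the compounds with values here, no pair of measured compounds differs in only one place, so no measured step sets the scale here. Still, compound 3 shows that a six-membered aromatic ring on the sulfonyl sulfur can give 17 nM. Compound 1, with its five-membered aromatic ring, stays at the limit. The step of an at least 16-fold lower number from compound 1 to compound 4 (1.22 log units; beyond the scatter) is therefore expected to be a gain in potency beyond the scatter, though with wide uncertainty. Compound 4 is estimated at 300 nM, within 40 nM to 3000 nM.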

Compound 4, half-maximal inhibitory concentration: 3700 nM
The estimate for compound 4 lay 12-fold (1.09 log units) below the measured number; measured number outside the range, above it.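

Swapping 1-methyl-1H-imidazol-4-yl for 6-chloropyridin-3-yl on the sulfonyl sulfur gives, in this assay, an at least 1.3-fold lower number from compound 1 to compound 4 (0.13 log units; that floor lies within the scatter). Compound 4 therefore has a number that can be read, but this step does not establish a real gain in potency. Its true size cannot be fixed because compound 1 gives only a limit and not a number: the limit of > 5000 nM in this assay, at which 2 of the 4 values shown sit. Within the data shown here, the step also shows that, on the core of compound 1, this six-membered aromatic ring does not guarantee a number as low as the one seen for compound 3, which differs from compound 4 in more than one place.

What separates compound 3 from compound 4 remains unresolved. As far as these compounds go, it is also open whether a plain phenyl ring, or a methoxy group in place of the chlorine, would change the number on this core.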